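This account rests on a few compounds, and the source may have more. Where it says the series, first, only, none or still open, it means among the compounds named here.

Compound 1 `CC[C@H](C)[C@H](NC(=O)c1cccc(Cn2ccnc2)c1)C(=O)Nc1nccs1`: 17%
Compound 2 `CCCCNC(=O)[C@@H](NC(=O)c1cccc(Cn2ccnc2)c1)[C@@H](C)CC`: 3%
Compound 3 `CCCCS(=O)(=O)NC(=O)[C@@H](NC(=O)c1cccc(Cn2ccnc2)c1)[C@@H](C)CC`: "not determined" (no result reported)

In an assay on HEK293 cells for displacement of a labelled ligand from Type-2 angiotensin II receptor (Homo sapiens), tested at 10 uM (a higher number here means a stronger effect of the compound at the concentration tested, a lower number a weaker effect), compound 1 gives 17%, while compound 2 gives 3%. Going by the values given here, the only measured step is a number 14 percentage points lower from compound 1 to compound 2 (beyond the scatter). Compound 3 has no number in this assay, so its own standing cannot be read off. Compound 4 `CC[C@H](C)[C@H](NC(=O)c1cccc(Cn2ccnc2)c1)C(=O)NNS(=O)(=O)c1ccccc1` differs from compound 3 by (phenylsulfonyl)amino in place of butylsulfonyl on an amide-type nitrogen. Among the compounds with values here, no measured step covers this exact change; the one measured step, a number 14 percentage points lower from compound 1 to compound 2 (beyond the scatter), also swaps a group on an amide-type nitrogen and was modest, and both measured values sit low. A low read-out is therefore expected for compound 4 too. Compound 4 is expected to give about 10% in this assay, estimated between 0% and 30%.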

Compound 4, a percentage reported as inhibition, at one concentration (the size of the read-out at that concentration, not a potency): 18%
Beside the measured number, compound 4's estimate is 8 percentage points below it; the range from low to high includes it.
By their numbers in this assay, from the lowest: compound 2; then compounds 1 and 4 (each within the scatter of the next).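

In this assay, (phenylsulfonyl)amino in place of butyl on an amide-type nitrogen gives a number 15 percentage points higher from compound 2 to compound 4 (beyond the scatter), so the group at this position can shift the read-out, if only modestly. In place of 1,3-thiazol-2-yl, the same group gives a number 1 percentage points higher from compound 1 to compound 4 (within the scatter), so these two groups cannot be told apart here. Nothing available explains either step.

The step from compound 3 to compound 4 cannot be read. On these data alone, what a carboxylic acid or an amine on this nitrogen would give remains open.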